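The source may report more compounds than this note shows. Statements on the series, on what has been measured and on what is new or still open speak of the compounds shown alone.

Compound 1 `Cc1ccc(NC(=O)/C=C/C(=O)N2C/C(=C\c3ccc([N+](=O)[O-])cc3)C(=O)/C(=C/c3ccc([N+](=O)[O-])cc3)C2)cc1C` was tested in a functional assay on CCRF-CEM cells (Homo sapiens) for cytotoxicity (a lower number here means a stronger inhibitor, a higher number a weaker inhibitor), where compound 1 gives 700 nM. This is the higher of the two numbers recorded so far. Compound 2 `COc1ccc(NC(=O)/C=C/C(=O)N2C/C(=C\c3ccccc3)C(=O)/C(=C/c3ccccc3)C2)cc1` differs from compound 1 in several places. In this assay compound 2 gives 510 nM, and the two values lie within the usual scatter of each other, so neither can be called the stronger inhibitor.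

The compound to follow is compound 3 `O=C(/C=C/C(=O)N1C/C(=C\c2ccc([N+](=O)[O-])cc2)C(=O)/C(=C/c2ccc([N+](=O)[O-])cc2)C1)Nc1ccc([N+](=O)[O-])cc1`, not yet measured. It is made from compound 1 by a single change: 4-nitrophenyl in place of 3,4-dimethylphenyl on an amide-type nitrogen. Among the measured compounds shown here, no measured pair shows what this change does on its own, so the expectation rests only on compound 1 itself. Nothing in the two values gives a reason to expect a move beyond the scatter in either direction, and the step is therefore estimated at no change at the digits printed from compound 1 to compound 3 (within the scatter), essentially none. Compound 3 is expected to give about 700 nM in this assay, with a plausible range from 250 nM to 2000 nM.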

Compound 3, half-maximal inhibitory concentration: 410 nM
Compound 3: the middle estimate sits 1.7-fold (0.23 log units) above what was measured; the range from low to high includes it.
By their numbers in this assay, from the lowest: compounds 3, 2 and 1 (each within the scatter of the next).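

In this assay, the first pair differing in one place gives a 1.7-fold lower number from compound 1 to compound 3 (0.23 log units; within the scatter), so this swap on the amide-type nitrogen cannot be read as a real difference in cytotoxicity. With the rest of the molecule unchanged, this position therefore accepts either 3,4-dimethylphenyl, whose added atoms are all carbon, or 4-nitrophenyl, which carries nitrogen and oxygen, with no effect beyond the scatter. No supporting measurement is available to explain this outcome.

A single pair cannot show whether other groups at this position would behave the same way. On these data alone, it remains open what an amine or a carboxylic acid on this aromatic ring would do, or a longer alkyl chain in place of the ring.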